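Aryl urea replacement on the shared core: compound 4

A few compounds are considered here, and "the series" means these few. Any claim that something is new, unique, unknown or untested is made for them only; others in the source may bear on it.

Measured values in a functional assay on MDA-MB-231 cells (Homo sapiens) for antiproliferative activity, read by MTT assay, with a stated time of 72 h (on this read-out lower numbers stand for stronger inhibition and higher numbers for weaker inhibition), for the three compounds in hand:

compound 1 `CC(=O)Nc1ccc(S(=O)(=O)Nc2cccc(-c3nc(-c4ccc(NC(=O)c5cccnc5)c(Cl)c4)no3)c2)cc1`: 4500 nM
compound 2 `O=C(Nc1cccc(-c2nc(-c3ccc(NC(=O)c4cccnc4)cc3Cl)no2)c1)Nc1cccc(C(F)(F)F)c1`: 1900 nM
compound 3 `O=C(Nc1cccc(-c2nc(-c3ccc(NC(=O)c4cccnc4)cc3Cl)no2)c1)Nc1cc(C(F)(F)F)cc(C(F)(F)F)c1`: 1900 nM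

Compound 2 and compound 3 stand level at the digits printed and together give the lowest two numbers of the three; compound 1 gives a higher number in this assay, and that gap lies beyond the scatter. Compound 4 `CS(=O)(=O)Nc1ccc(NC(=O)Nc2cccc(-c3nc(-c4ccc(NC(=O)c5cccnc5)cc4Cl)no3)c2)cc1Br` is the next step from compound 2: 3-bromo-4-(methanesulfonamido)phenyl in place of 3-(trifluoromethyl)phenyl on an amide-type nitrogen.

Among the compounds with values here, only one measured step touches the same aryl on the amide-type nitrogen, no change at the digits printed from compound 2 to compound 3 (within the scatter). That step adds a second trifluoromethyl and leaves the number unchanged, so substitution on this ring has so far been tolerated. Nothing measured covers a methanesulfonamido group or a bromine in this position, and compound 1 carries its sulfonamide in a different place, so it gives no direct guide. The expectation is therefore a small step, a 1.1-fold higher number from compound 2 to compound 4 (0.02 log units; within the scatter), within the scatter. Compound 4 is expected to give about 2000 nM in this assay, in the range 700 nM to 6000 nM.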

Compound 4, half-maximal inhibitory concentration: 700 nM
Compound 4: the middle estimate sits 2.9-fold (0.46 log units) above what was measured, and the stated range covers the measured number.
By their numbers in this assay, from the lowest: compound 4; then compounds 2 and 3 (each within the scatter of the next); then compound 1.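

In this assay the aryl group on the amide-type nitrogen now shows that this position can move the number: the change to 3-bromo-4-(methanesulfonamido)phenyl gives a 2.7-fold lower number from compound 2 to compound 4 (0.43 log units; beyond the scatter) as a modest step, whereas the earlier trifluoromethyl addition gave no change at the digits printed from compound 2 to compound 3 (within the scatter) and showed only tolerance. Because bromine and methanesulfonamido enter together while trifluoromethyl leaves, this single step cannot assign the gain to any one of these groups. Nothing available here accounts for the lower number.

The compounds shown leave open whether the methanesulfonamido group without the bromine, or the bromine without the methanesulfonamido group, would give the same step. Going by these compounds, it also remains open whether a carboxylic acid or an amine in place of the methanesulfonamido group would keep the number at this level.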